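Compound 4 against the measured heteroaryl groups

This account rests on a few compounds, and the source may have more. Where it says the series, first, only, none or still open, it means among the compounds named here.

Measured in a physicochemical assay for lipophilicity, using the shake flask method, in phosphate buffer, measured as octanol-water partition, with a stated time of 30 min, at pH 7.4; a higher number here means a more lipophilic compound, a lower number a more polar compound:
- compound 1 `Cn1cc(-c2cnc(NCc3c(F)ccc4c3CCO4)c3cn[nH]c(=O)c23)cn1`: 2.7
- compound 2 `O=C1CCCN1c1cnc(NCc2c(F)ccc3c2CCO3)c2cn[nH]c(=O)c12`: 1.8
- compound 3 `CNC(=O)c1ncc(-c2cnc(NCc3c(F)ccc4c3CCO4)c3cn[nH]c(=O)c23)n1C`: 2.5

The standing of compound 3 rests on two measured steps: a number 0.20 log units lower from compound 1 to compound 3 (within the scatter), and a number 0.70 log units higher from compound 2 to compound 3 (beyond the scatter). Compound 3 thus stands with compound 1 at the upper end of this short range, apart from compound 2.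

The next case is compound 4 `Cc1nn(C)cc1-c1cnc(NCc2c(F)ccc3c2CCO3)c2cn[nH]c(=O)c12`: 1,3-dimethyl-1H-pyrazol-4-yl in place of 1-methyl-2-(methylcarbamoyl)-1H-imidazol-5-yl on an aromatic carbon, with 1,3-dimethyl-1H-pyrazol-4-yl in place of 1-methyl-2-(methylcarbamoyl)-1H-imidazol-5-yl on an aromatic carbon. The step bearing most directly is a number 0.20 log units lower from compound 1 to compound 3 (within the scatter): it links the leaving group to 1-methyl-1H-pyrazol-4-yl, the closest measured group to the entering one. The other two steps, a number 0.90 log units lower from compound 1 to compound 2 (beyond the scatter) and a number 0.70 log units higher from compound 2 to compound 3 (beyond the scatter), run through 2-oxopyrrolidin-1-yl and bear less. Within the data shown here, no measured compound carries the entering group itself.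

A small rise in this assay is expected, taking compound 1 at 2.7 as the nearest guide. The expected step is a number 0.40 log units higher from compound 3 to compound 4 (beyond the scatter). Compound 4 is estimated at 2.9, with an expected range of 2.5 to 3.3.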

Compound 4, distribution coefficient: 2.8
Compound 4: the middle estimate sits 0.10 log units above what was measured; the range from low to high includes it.
By their numbers in this assay, from the lowest: compound 2; then compounds 3, 1 and 4 (each within the scatter of the next).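

In this assay, among these compounds, methyl in place of hydrogen on an aromatic carbon of the 1-methyl-1H-pyrazol-4-yl group gives a number 0.10 log units higher from compound 1 to compound 4 (within the scatter), the first reading of a change made on that group itself. 1,3-Dimethyl-1H-pyrazol-4-yl in place of 1-methyl-2-(methylcarbamoyl)-1H-imidazol-5-yl gives a number 0.30 log units higher from compound 3 to compound 4 (within the scatter), whereas 2-oxopyrrolidin-1-yl remains the one group set apart at this position, with a number 1.00 log units higher from compound 2 to compound 4 (beyond the scatter). Nothing at hand accounts for this grouping of the values.

Going by these compounds, whether an amine or a carboxylic acid on this aromatic carbon would fall with compound 2 or with compounds 1, 3 and 4 remains open. Also open, on these data alone, is whether an ethyl or longer chain in place of the added methyl would stay within the scatter of compound 1.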